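Methyl to tert-Butyl on the Ring Nitrogen

This account rests on a few compounds, and the source may have more. Where it says the series, first, only, none or still open, it means among the compounds named here.

Of the compounds shown here, three sharing one core have been measured in an in vivo ADME assay on the whole organism for metabolic stability, with Mus musculus as the target, read by LC-MS, at a dose of 160 mg/kg by the oral route; on this read-out higher numbers stand for a longer-lived compound and lower numbers for a shorter-lived compound. Compound 1, `CC(C)N1CC(=O)N=C1NC(=N)Nc1ccc(Cl)c(Cl)c1`, gives 0.667 h. Compound 2, `CN1CC(=O)N=C1NC(=N)Nc1ccc(Cl)c(Cl)c1`, carries a methyl in place of that isopropyl, and compound 2 gives > 1 h, which is a limit of the assay rather than a number. Compound 3, `CC(C)(C)N/C(=N/C1=NC(=O)CN1c1ccc(Cl)c(Cl)c1)Nc1ccc(Cl)c(Cl)c1`, likewise reaches only a limit, giving > 1 h. For the measured compounds named here, the one step between measured neighbours, an at least 1.4-fold higher number from compound 1 to compound 2 (0.17 log units; that floor lies within the scatter), points toward a longer-lived compound, though its floor lies within the scatter; the picture is shaped by the limit of > 1 h in this assay, at which 2 of the 3 values shown sit, where two of the three readings sit. Compound 2 therefore stands at that limit and cannot be placed more precisely.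

Compound 4, `CC(C)(C)N1CC(=O)N=C1NC(=N)Nc1ccc(Cl)c(Cl)c1`, differs from compound 2 by tert-butyl in place of methyl on an amine nitrogen in a ring. Going by the values given here, the only measured step bearing on it is the same exchange at the same ring nitrogen, but in the opposite sense and with a different group, so it offers a weak guide; compound 3, which also carries a tert-butyl, also reaches the limit. The expectation in this assay is a change of a step that the limit leaves unreadable from compound 2 to compound 4, expected to stay within the scatter. Compound 4 is estimated at 1.2 h, within a range from 0.5 h to 2.5 h.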

Compound 4, half-life: > 1 h
Compound 4: only a limit was reported (the forecaster's own chance of this, stated with the estimate: 55%); the middle value does not contradict the limit.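

Moving from methyl to tert-butyl on the ring nitrogen leaves a step that cannot be read in this assay, because compound 2 and compound 4 both stop at the same limit rather than giving numbers: the limit of > 1 h in this assay, at which 3 of the 4 values shown sit.

What the new compound adds is a second comparison at this ring nitrogen: one more methyl on the isopropyl carbon turns isopropyl into tert-butyl and gives an at least 1.4-fold higher number from compound 1 to compound 4 (0.17 log units; that floor lies within the scatter). For the compounds shown here, until now, the only readable change at this position was the exchange of isopropyl for methyl, which could have suggested that a smaller group goes with a longer-lived compound, but the larger tert-butyl also reaches the limit, so the data give no support for a simple trend with group size, and compound 1 is the only one of this series with a reading that is a number.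

From the compounds shown here alone, how far compound 2 and compound 4 lie beyond the limit, and whether either truly differs from compound 1, stays open. So does the reading of this ring nitrogen with a longer chain, or with a chain ending in an amine or a carboxylic acid.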